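Ring size at the ester of a naphthoquinone series

A few compounds are considered here, and "the series" means these few. Any claim that something is new, unique, unknown or untested is made for them only; others in the source may bear on it.

The measured compounds and their values:
Compound 1, `COC(C)CO[C@H](CC=C(C)C)C1=CC(=O)c2c(O)ccc(O)c2C1=O`, gives 16600 nM in a functional assay on DU-145 cells (Homo sapiens) for cytotoxicity, read by MTT assay; on this read-out lower numbers stand for stronger inhibition and higher numbers for weaker inhibition.
Compound 2, `CC(=O)OCCC(=O)O[C@H](CC=C(C)C)C1=CC(=O)c2c(O)ccc(O)c2C1=O`, gives 15700 nM in this assay.
Compound 3, `CC(C)=CC[C@@H](OC(=O)C1CCOC1)C1=CC(=O)c2c(O)ccc(O)c2C1=O`, gives 47500 nM in this assay.

Among these three, compound 3 has the highest number in this assay, so it is the weakest of the set: the step of a 2.9-fold higher number from compound 1 to compound 3 (0.46 log units; beyond the scatter) and the step of a 3.0-fold higher number from compound 2 to compound 3 (0.48 log units; beyond the scatter) are both beyond the scatter, while a 1.1-fold lower number from compound 1 to compound 2 (0.02 log units; within the scatter) is not.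

Compound 4, `CC(C)=CC[C@@H](OC(=O)C1CCCOC1)C1=CC(=O)c2c(O)ccc(O)c2C1=O`, has not yet been measured. It differs from compound 3 in one place: oxan-3-yl in place of oxolan-3-yl on a carbonyl carbon. The group that enters keeps one hydrogen-bond acceptor and no charge, and the ring grows from a five-membered non-aromatic ring to a six-membered non-aromatic ring.

For the measured compounds named here, only one measured step touches the same position, the carbonyl carbon: a 3.0-fold higher number from compound 2 to compound 3 (0.48 log units; beyond the scatter), a modest change, but it swaps an open chain for a ring rather than one ring for a slightly larger one. Going by the values given here, no measured step shows the effect of widening a ring by one atom. The expectation is therefore a small step, a 1.1-fold lower number from compound 3 to compound 4 (0.05 log units; within the scatter), in either direction and most likely within the scatter. Compound 4 is estimated at 42000 nM, with a plausible range from 18000 nM to 100000 nM.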

Compound 4, half-maximal inhibitory concentration: 29700 nM
For compound 4 the middle estimate is 1.4-fold (0.15 log units) above the measured one; measured number inside the range.
By their numbers in this assay, from the lowest: compounds 2, 1, 4 and 3 (each within the scatter of the next, the first and the last beyond it).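

Going from the five-membered oxolan-3-yl to the six-membered oxan-3-yl on this carbonyl carbon gives a 1.6-fold lower number from compound 3 to compound 4 (0.20 log units; within the scatter) in this assay, so the first ring-size change seen at this position does not separate the two compounds by more than ordinary repeat-measurement noise. Compound 4 also lies within the scatter of the two compounds with open chains, whether the comparison is the exchange of 2-acetoxyethyl for oxan-3-yl, a 1.9-fold higher number from compound 2 to compound 4 (0.28 log units; within the scatter), or the larger exchange of 2-methoxypropyl for (oxan-3-yl)carbonyl, a 1.8-fold higher number from compound 1 to compound 4 (0.25 log units; within the scatter). For the compounds shown here, compound 3 therefore remains the only member of the set clearly separated from compounds 1 and 2, and a saturated ring at this carbonyl carbon does not in itself go with a clearly higher number, since compound 4 carries one without that separation.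

Still open, going by these compounds, is whether a ring holding an amine, such as piperidin-3-yl, or a carboxylic acid on this carbonyl carbon would move the number beyond the scatter. Nothing available here accounts for the differences among these compounds.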